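The compounds below may be only part of what the source reports. "The series", "measured", "known", "first", "only" and "open" are said of these compounds alone.

Measured so far:
compound 1 `CC(C)n1c(=O)n(C(=O)NCCN2CCNCC2)c2ccccc21`, 7.94 nM
compound 2 `COc1ccc2[nH]cc(C(=O)NC3CCNCC3)c2c1`, 100000000 nM
compound 3 `CCN1CCC(NC(=O)c2cc(Cl)c(N)cc2OC)CC1`, 79.4 nM

The numbers come from a functional assay on HEK293 cells for agonist activity at 5-hydroxytryptamine receptor 4 (Homo sapiens), read by cAMP accumulation; a higher number here means that more compound is needed for the effect, a lower number that less compound is needed. Among the three, compound 3 stands second highest: compound 1 needs a lower number, beyond the usual scatter, and compound 2 sits far above both, the most distant of the three.

Compound 4 `COc1cc(N)c(Cl)cc1C(=O)NC1CCN(CCCCCO)CC1` is not yet measured. It differs from compound 3 in one place: 3-hydroxypropyl in place of hydrogen on a saturated chain carbon, two bonds along the chain from an amine nitrogen in a ring. Everything else in the molecule stays the same, so whatever compound 4 shows in this assay can be set directly against the number of compound 3.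

Within the data shown here, no measured pair in this set shares this kind of change, so there is no directly comparable step to lean on. The change adds a short chain carrying one hydroxyl at the end of the group on the ring nitrogen, and the rest of the scaffold of compound 3 is kept. The expectation for compound 4 is a small move toward a lower number, close enough to the scatter that no change at all would also be unsurprising, amounting to a 2.3-fold lower number from compound 3 to compound 4 (0.36 log units; beyond the scatter). In this assay compound 4 is therefore estimated at 35 nM, with a likely range from 6 nM to 200 nM.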

Compound 4, half-maximal effective concentration: 15.9 nM
The estimate for compound 4 lay 2.2-fold (0.34 log units) above the measured number; measured number inside the range.
By their numbers in this assay, from the lowest: compounds 1 and 4 (each within the scatter of the next); then compound 3; then compound 2.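

Among these compounds, the step of a 5.0-fold lower number from compound 3 to compound 4 (0.70 log units; beyond the scatter) in this assay is the first direct reading of a change at this position, where an ethyl group grows into 5-hydroxypentyl while the rest of the molecule stays the same. It shows that a saturated chain carbon, two bonds along the chain from an amine nitrogen in a ring, can carry a 3-hydroxypropyl group without the compound needing more for the effect; here it needs less, by more than the usual scatter of repeated measurements. This is one pair in one assay, and no measurement shown here accounts for the size or direction of the step.

The pair cannot separate the contribution of the longer chain from that of the hydroxyl at its end, and a plain pentyl chain with no hydroxyl would be the direct test of this. Also open, from the compounds shown here alone, is how the number responds to other ends on the chain, such as an amine or a carboxylic acid, or to a still longer chain carrying the same hydroxyl.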